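Halogen exchange on the cinnamate ring of compound 2

The source may report more compounds than this note shows. Statements on the series, on what has been measured and on what is new or still open speak of the compounds shown alone.

For the measured compounds named here, compound 2 `CN(C)CC1CCC/C(=C\c2ccc(OC(=O)/C=C/c3ccc(F)cc3)cc2)C1=O` gives the lower of the two numbers known so far in a functional assay on L1210 cells (Mus musculus) (on this read-out higher numbers stand for weaker inhibition and lower numbers for stronger inhibition), with a reading of 1840 nM; its nearest neighbour is compound 1 `CN(C)CC1CCC/C(=C\c2ccc(OC(=O)/C=C/c3ccccc3)cc2)C1=O`, which in this assay gives 32800 nM. Going by the values given here, the single measured step between them, an 18-fold lower number from compound 1 to compound 2 (1.25 log units; beyond the scatter), is the only comparison available. Compound 3 `CN(C)CC1CCC/C(=C\c2ccc(OC(=O)/C=C/c3ccc(Cl)c(Cl)c3)cc2)C1=O` differs from compound 2 in one place: 3,4-dichlorophenyl in place of 4-fluorophenyl on a double-bonded chain carbon bound to a double-bonded chain carbon. Among the compounds with values here, no measured pair shows this exact exchange, so the step from compound 1 to compound 2 bears on it only loosely, as a change of halogen substitution on the same aromatic ring. That step was large, yet it went from hydrogen to fluoro, not from one halogen pattern to another, and it offers no direct guide to the direction of the present change. A modest step in this assay, within or not far beyond the scatter, is expected, with a lower number somewhat more likely than a higher one. Compound 3 is therefore estimated at 1500 nM, between 400 nM and 6000 nM, corresponding to the expected step of a 1.2-fold lower number from compound 2 to compound 3 (0.09 log units; within the scatter).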

Compound 3, half-maximal inhibitory concentration: 3310 nM
Compound 3: middle estimate off by 2.2-fold (0.34 log units), on the low side, and the stated range covers the measured number.
By their numbers in this assay, from the lowest: compounds 2 and 3 (each within the scatter of the next); then compound 1.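

In this assay, putting 3,4-dichlorophenyl in place of 4-fluorophenyl on a double-bonded chain carbon bound to a double-bonded chain carbon gives a 1.8-fold higher number from compound 2 to compound 3 (0.26 log units; within the scatter), so on this read-out the two halogen patterns cannot be told apart. Measured from the plain phenyl, the dichlorinated ring gives a 9.9-fold lower number from compound 1 to compound 3 (1.00 log units; beyond the scatter), which means that the separation from compound 1 is no longer tied to fluorine alone: both halogen-bearing compounds shown stand apart from compound 1 in the same direction, and none of the three goes against this, although two compounds are a narrow basis for it. No experimental information is available that would account for these readings at this position.

The compounds shown leave open whether a single chloro, a bromo or a trifluoromethyl group on the same ring would read with compound 2 and compound 3 or with compound 1. They also leave open how a ring carrying no halogen but a methoxy group, a nitrile, an amine or a carboxylic acid would read in this assay.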